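Moving the bromine around the phenoxy ring

The source may hold more compounds than are shown below. What is called first, only, known or untested is meant among the compounds shown, and "the series" means these compounds.

Compound 1 `NC1=NC2(CCOCC2)N(OCCCOc2ccccc2Cl)C(N)=N1` and compound 2 `NC1=NC2(CCOCC2)N(OCCCOc2ccccc2Br)C(N)=N1` share one core and differ only by bromo in place of chloro on an aromatic carbon. In an assay on isolated protein for inhibition of Dihydrofolate reductase (Homo sapiens), read by spectrophotometry, using NADPH, with stated times of 5 s and 6 min, tested at 5 uM (on this read-out lower numbers stand for a weaker effect and higher numbers for a stronger effect at the one concentration tested), compound 1 gives 83.3% and compound 2 gives 83.8%; the step of a number 0.5 percentage points higher from compound 1 to compound 2 (within the scatter) leaves the pair within the scatter, so compound 2 stands level with compound 1 on the numbers shown. Compound 3 `NC1=NC2(CCOCC2)N(OCCCOc2cccc(Br)c2)C(N)=N1` keeps every atom of compound 2, joined differently: 3-bromophenyl in place of 2-bromophenyl on an oxygen on a saturated carbon. Within the data shown here, no measured step moves the halogen around this ring; the one step touching it, a number 0.5 percentage points higher from compound 1 to compound 2 (within the scatter), was flat, so no step beyond the scatter is expected in this assay, giving a number 3.8 percentage points lower from compound 2 to compound 3 (within the scatter). Compound 3 is therefore estimated at 80%, between 65% and 90%.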

Compound 3, a percentage reported as inhibition, at one concentration (the size of the read-out at that concentration, not a potency): 86.7%
The estimate for compound 3 lay 6.7 percentage points below the measured number; measured number inside the range.
By their numbers in this assay, from the lowest: compounds 1, 2 and 3 (each within the scatter of the next).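

In this assay the 3-bromophenyl in place of 2-bromophenyl on an oxygen on a saturated carbon gives a number 2.9 percentage points higher from compound 2 to compound 3 (within the scatter) and so does not separate these two bromine isomers. Changing both halogen and ring position, 3-bromophenyl in place of 2-chlorophenyl, gives a number 3.4 percentage points higher from compound 1 to compound 3 (within the scatter) and leaves this pair level too. Nothing available bears on why these changes leave the read-out level.

From the compounds shown here alone, whether an amine or a carboxylic acid in place of the bromine would give a step beyond the scatter remains open. The read-out comes from a single concentration and shows only the size of the effect at that concentration.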